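A few compounds are considered here, and "the series" means these few. Any claim that something is new, unique, unknown or untested is made for them only; others in the source may bear on it.

Measured in a functional assay on PC-3 cells (Homo sapiens) for antiproliferative activity, with a stated time of 48 h; a higher number here means a weaker inhibitor, a lower number a stronger inhibitor:
Compound 1 `CCN(CC)c1ccc(-c2cccc(OC)c2)nn1`: > 25000 nM (a limit).
Compound 2 `CC(=O)c1ccc(-c2ccc(N3CCCC3)nn2)cc1`: > 25000 nM (a limit).
Compound 3 `CCN(CC)c1ccc(-c2cccc(Cl)c2)nn1`: > 25000 nM (a limit).

All three readings share one end point: the limit of > 25000 nM in this assay, at which 3 of the 3 values shown sit. Compound 2 therefore has no numerical value, and its > 25000 nM is only a limit.

The next change leads to compound 4 `CCN(CC)c1ccc(-c2ccc(C(C)=O)cc2)nn1`, with diethylamino in place of pyrrolidin-1-yl on an aromatic carbon.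

Going by the values given here, no measured pair tests this exchange. Among the compounds with values here, the one available step, a step that the two limits leave unreadable from compound 1 to compound 3, concerns chloro in place of methoxy, so it gives no size to carry over. Compound 3 already carries diethylamino, and its > 25000 nM is a limit. Compound 1 also carries diethylamino, and its > 25000 nM is a limit as well.

No change beyond the scatter is expected in this assay, and the expected step is a step that the limit leaves unreadable from compound 2 to compound 4. A limit reading is the most likely outcome. For compound 4 the estimate is 30000 nM, with an expected range of 12000 nM to 60000 nM.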

Compound 4, half-maximal inhibitory concentration: > 25000 nM
Compound 4: no number, only a limit; the forecaster's own chance of this, stated with the estimate: 80%; the middle value does not contradict the limit.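

Diethylamino in place of pyrrolidin-1-yl gives no readable step between compound 2 and compound 4, since both readings are limits and not numbers: the limit of > 25000 nM in this assay, at which 4 of the 4 values shown sit. The compounds shown leave open which change, if any, would bring a numerical value in this assay.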